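A few compounds are considered here, and "the series" means these few. Any claim that something is new, unique, unknown or untested is made for them only; others in the source may bear on it.

Working notes on the series. Compound 1 `CC(C)=CCCC1=CC[C@H](C(=O)Nc2ccc(O)cc2)[C@@H](c2ccccc2)C1` is known in an assay on isolated protein for inhibition of Apoptosis regulator Bcl-2 (Homo sapiens), read by fluorescence polarization, with stated times of 5 min and 10 min (on this read-out higher numbers stand for weaker inhibition and lower numbers for stronger inhibition), only as a limit, and that limit is > 23000 nM. Compound 3 `CC(C)=CCCC1=CC[C@@H](C(=O)Nc2ccc(O)cc2)[C@H](c2ccccc2)C1` is the mirror image of the earlier compound, and compound 3 likewise reaches only the limit > 23000 nM. Compound 2 `CON(C)C(=O)[C@@H]1CC2=C(CCCC2(C)C)C[C@H]1c1ccccc1` also stops at the limit > 23000 nM. For the measured compounds named here, the single one-place step in the set, a step that the two limits leave unreadable from compound 1 to compound 3, cannot be read because the limit of > 23000 nM in this assay, at which 3 of the 3 values shown sit, holds for both ends. Compound 4 `CONC(=O)[C@H]1CC=C(CCC=C(C)C)C[C@@H]1c1ccccc1` differs from compound 1 by methoxy in place of 4-hydroxyphenyl on an amide-type nitrogen. Going by the values given here, no measured step touches this change, so nothing in the numbers points in either direction. Compound 4 is expected to sit at the limit again, with a step that the limit leaves unreadable from compound 1 to compound 4 as the estimated step. The estimate for compound 4 is 40000 nM, ranging from 15000 nM to 150000 nM.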

Compound 4, inhibition constant: 2400 nM
Beside the measured number, compound 4's estimate is 17-fold (1.22 log units) above it; the whole stated range lies above it.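

On the amide-type nitrogen, methoxy in place of 4-hydroxyphenyl gives an at least 9.5-fold lower number from compound 1 to compound 4 (0.98 log units; beyond the scatter) in this assay, so this position can carry a change that moves the read-out clear of the limit. Compound 4 is the only compound shown with a measured number rather than a limit: the limit of > 23000 nM in this assay, at which 3 of the 4 values shown sit. The true size of the step stays unknown, since the value for compound 1 is only a limit.

Going by these compounds, it remains open whether ethoxy or a plain hydroxyl on the same nitrogen would keep this gain, and whether the mirror image of compound 4 would match it.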